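Cyclooctyl in place of cyclopropyl: working notes

A few compounds are considered here, and "the series" means these few. Any claim that something is new, unique, unknown or untested is made for them only; others in the source may bear on it.

Values so far in a functional assay on MIA PaCa-2 cells (Homo sapiens) for cytotoxicity, read by fluorescence, with a stated time of 48 h (a lower number here means that less compound is needed, a higher number that more compound is needed for the effect), are as follows.

- compound 1 `CC(C)=CCC/C(C)=C/CC/C(C)=C/CSC[C@H](NC(=O)CCCCCN1CCCC1)C(=O)NC1CCCC1` gives 3200 nM
- compound 2 `CC(C)=CCC/C(C)=C/CC/C(C)=C/CSC[C@H](NC(=O)CCCCCN1CCN(C)CC1)C(=O)NC1CC1` gives 10400 nM

Compound 2 stands at the higher of the two numbers, and its gap to compound 1 lies beyond the scatter. More compound is therefore needed for the effect with compound 2 than with compound 1.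

The next structure is compound 3 `CC(C)=CCC/C(C)=C/CC/C(C)=C/CSC[C@H](NC(=O)CCCCCN1CCN(C)CC1)C(=O)NC1CCCCCCC1`, which has cyclooctyl in place of cyclopropyl on an amide-type nitrogen. For the measured compounds named here, no measured pair isolates this change, so the expectation is weakly grounded. Going by the values given here, with compound 1 at 3200 nM as the only lower number, a lower number is the likelier direction. The expected change in this assay is a 2.3-fold lower number from compound 2 to compound 3 (0.36 log units; beyond the scatter), and its size remains uncertain. For compound 3 the estimated value is 4500 nM, with an expected range of 1500 nM to 12000 nM.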

Compound 3, half-maximal effective concentration: 2500 nM
Beside the measured number, compound 3's estimate is 1.8-fold (0.26 log units) above it, and the stated range covers the measured number.
By their numbers in this assay, from the lowest: compounds 3 and 1 (each within the scatter of the next); then compound 2.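

In this assay, with the rest of the structure unchanged, cyclooctyl in place of cyclopropyl on an amide-type nitrogen gives a 4.2-fold lower number from compound 2 to compound 3 (0.62 log units; beyond the scatter). For the compounds shown here, the earlier compounds differed from each other in more than one place, so this is the first step that isolates this position. It shows that the carbon ring on this nitrogen can by itself move the number beyond the scatter, with the larger ring on the lower side in this pair. No available evidence bears on the reason for the step.

Two ring sizes on this nitrogen cannot show whether the number follows ring size steadily or whether intermediate rings behave differently. A cyclohexyl ring, an open-chain hexyl group or a ring carrying a carboxylic acid would each test how far the step extends.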